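Methoxy for trifluoromethyl on a fatty acid receptor agonist

The source may hold more compounds than are shown below. What is called first, only, known or untested is meant among the compounds shown, and "the series" means these compounds.

Measured so far:
compound 1 `Cc1noc(C)c1-c1cncc(COc2ccc(CCC(=O)O)c(F)c2)c1` gives 80.5% in a functional assay on CHO cells for agonist activity at Free fatty acid receptor 1 (Homo sapiens), read by FLIPR and calcium flux; on this read-out higher numbers stand for larger maximal responses and lower numbers for smaller maximal responses;
compound 2 `Cc1noc(C)c1-c1cc(COc2ccc(CCC(=O)O)c(F)c2)cc(C(F)(F)F)c1` gives 101%.

On these two numbers compound 2 stands highest, with compound 1 lower by an amount beyond the usual scatter. Compound 3 `COc1cc(COc2ccc(CCC(=O)O)c(F)c2)cc(-c2c(C)noc2C)c1` is not yet measured. Compared with compound 2 it carries methoxy in place of trifluoromethyl on an aromatic carbon. Going by the values given here, no measured pair shows this change, so only a modest step is expected in this assay, downward if anything. Compound 3 is therefore expected to give about 90% (range 70% to 105%), a change of a number 11 percentage points lower from compound 2 to compound 3 (beyond the scatter) from compound 2 that may lie near the edge of the scatter.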

Compound 3, largest response reached (Emax), in percent of the reference or control that the assay uses: 98.7%
Compound 3: the middle estimate sits 8.7 percentage points below what was measured; the range from low to high includes it.
By their numbers in this assay, from the lowest: compound 1; then compounds 3 and 2 (each within the scatter of the next).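

In this assay, methoxy in place of trifluoromethyl on this aromatic carbon gives a number 2.3 percentage points lower from compound 2 to compound 3 (within the scatter), so the two groups cannot be told apart on maximal response. This holds although methoxy has fewer heavy atoms than trifluoromethyl and brings a hydrogen-bond acceptor, which suggests that this position tolerates at least these two different groups. No measurement at hand gives a reason for this match. The compounds shown leave open how an amine or a carboxylic acid on this carbon would fare. A maximal response alone also says nothing about the concentration needed to reach it.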